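Swapping hydroxy for trifluoromethyl on the aryl urea of compound 3

This account rests on a few compounds, and the source may have more. Where it says the series, first, only, none or still open, it means among the compounds named here.

Compound 3 `COc1cc(NC(C)CCCNC(=O)Nc2cccc(O)c2)c2ncccc2c1` gives 25000 nM in a functional assay on L1210 cells (Mus musculus) for inhibition, read by MTT assay, with a stated time of 72 h (on this read-out higher numbers stand for weaker inhibition and lower numbers for stronger inhibition), the lowest number of the three measured. Compound 2 `COc1cc(NC(C)CCCNC(=O)NNC(=O)Nc2cccc(Cl)c2)c2ncccc2c1` gives 27000 nM, and a 1.1-fold lower number from compound 2 to compound 3 (0.03 log units; within the scatter). Compound 1 `COc1cc(NC(C)CCCNC(=O)NNC(=O)Nc2ccc(O)cc2)c2ncccc2c1` gives 95000 nM; a 3.8-fold lower number from compound 1 to compound 3 (0.58 log units; beyond the scatter) and a 3.5-fold lower number from compound 1 to compound 2 (0.55 log units; beyond the scatter). Compound 4 `COc1cc(NC(C)CCCNC(=O)Nc2cccc(C(F)(F)F)c2)c2ncccc2c1` is not yet measured; it differs from compound 3 by trifluoromethyl in place of hydroxy on an aromatic carbon. For the measured compounds named here, the only step that bears on it is the one from compound 1 to compound 2, where a 3-hydroxyphenyl-type group gave way to a halogenated phenyl and the number fell modestly. A modest fall, or none beyond the scatter, is therefore expected, as a 1.7-fold lower number from compound 3 to compound 4 (0.22 log units; within the scatter). For compound 4 the estimated value in this assay is 15000 nM, with a range from 6000 nM to 40000 nM.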

Compound 4, half-maximal inhibitory concentration: 9200 nM
For compound 4 the middle estimate is 1.6-fold (0.21 log units) above the measured one; the range from low to high includes it.
By their numbers in this assay, from the lowest: compound 4; then compounds 3 and 2 (each within the scatter of the next); then compound 1.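

In this assay there is a 2.7-fold lower number from compound 3 to compound 4 (0.43 log units; beyond the scatter), so at this aromatic carbon the hydroxy can be replaced by trifluoromethyl, which has no hydrogen-bond donor, and the number still falls beyond the scatter. There is also a 2.9-fold lower number from compound 2 to compound 4 (0.47 log units; beyond the scatter) and a 10-fold lower number from compound 1 to compound 4 (1.01 log units; beyond the scatter), which sets compound 4 apart from compounds 2 and 3, themselves within the scatter of each other. Nothing measured here says why the number falls. Left open is whether a methyl, a chlorine or a nitrile on this carbon would match trifluoromethyl, and how an amine or a carboxylic acid there would read.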